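Notes on the 2-hydroxyethyl step to compound 4

A few compounds are considered here, and "the series" means these few. Any claim that something is new, unique, unknown or untested is made for them only; others in the source may bear on it.

Values so far in a functional assay for inhibition, read by fluorescence and spectrophotometry, with a stated time of 30 h; on this read-out lower numbers stand for stronger inhibition and higher numbers for weaker inhibition
compound 1 (`COc1ccc(-c2cc(=O)c3ccc(OCCCN4CCC(C)CC4)cc3o2)cc1`) at 42600 nM
compound 2 (`COc1ccc(-c2cc(=O)c3ccc(OCCCN4CCC(CCO)CC4)cc3o2)cc1`) at 43200 nM
compound 3 (`COc1ccc(-c2cc(=O)c3ccc(OCCCCN4CCC(C)CC4)cc3o2)cc1`) at 48200 nM

The three values do not separate. The steps of a 1.1-fold higher number from compound 1 to compound 3 (0.05 log units; within the scatter) and a 1.1-fold higher number from compound 2 to compound 3 (0.05 log units; within the scatter) both lie within the scatter, so compound 3 stands level with the other two and no order can be read among them.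

The next compound is compound 4 (`COc1ccc(-c2cc(=O)c3ccc(OCCCCN4CCC(CCO)CC4)cc3o2)cc1`). It differs from compound 3 by one change (hydroxymethyl in place of hydrogen on a saturated chain carbon bound to a saturated ring carbon). Cut one bond further out, this reads methyl to 2-hydroxyethyl.

The same change has one measured precedent, the step of a 1.0-fold higher number from compound 1 to compound 2 (0.01 log units; within the scatter) and it lies within the scatter. That is a single pair, on the chain of compound 1 rather than that of compound 3, so the evidence is thin. Even so, nothing measured points to a shift, and no step beyond the scatter is expected in this assay in either direction. The expected step is a 1.0-fold lower number from compound 3 to compound 4 (0.00 log units; within the scatter) and it is taken as no real change. For compound 4 the estimate is 48000 nM with an expected range from 29000 nM to 80000 nM in this read-out.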

Compound 4, half-maximal inhibitory concentration: 38400 nM
For compound 4 the middle estimate is 1.3-fold (0.10 log units) above the measured one; the measured number falls inside the stated range.
By their numbers in this assay, from the lowest: compounds 4, 1, 2 and 3 (each within the scatter of the next).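

In this assay the change from methyl to 2-hydroxyethyl now has a second reading, a 1.3-fold lower number from compound 3 to compound 4 (0.10 log units; within the scatter), so the earlier result no longer rests on a single pair. The two readings agree on two cores: the same change on two cores in this assay, a 1.0-fold higher number (0.01 log units; within the scatter) from compound 1 to compound 2 and a 1.3-fold lower number (0.10 log units; within the scatter) from compound 3 to compound 4, 1.3-fold (0.10 log units) apart, within the scatter of two such steps.

The chain step read with 2-hydroxyethyl in place gives a 1.1-fold lower number from compound 2 to compound 4 (0.05 log units; within the scatter), and the pair that differs in both features gives a 1.1-fold lower number from compound 1 to compound 4 (0.05 log units; within the scatter), so in these four compounds neither feature, alone or together, moves the number beyond the scatter.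

Going by these compounds, what stays open is whether any group at this place separates from the others in this assay, since 2-hydroxyethyl and methyl are the only two compared here. A carboxylic acid or an amine in place of the hydroxyl of 2-hydroxyethyl, or a longer chain between the aromatic oxygen and 4-methylpiperidin-1-yl, would test whether this flat reading holds beyond these four compounds.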